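This account rests on a few compounds, and the source may have more. Where it says the series, first, only, none or still open, it means among the compounds named here.

Measured so far, in an assay on CHO cells for antagonist activity at transient receptor potential cation channel subfamily V member 1 (Homo sapiens), read by scintillation counting, with a stated time of 5 min, in the presence of a further agent that is not named here; on this read-out lower numbers stand for an effect already at smaller amounts and higher numbers for an effect only at larger amounts of compound:
- compound 1, `CN(C)C1(Cc2ccccc2)CCN(c2cc(C(F)(F)F)ccc2CNC(=O)Nc2ccc(CO)c(F)c2)CC1`: 81 nM
- compound 2, `CN(C)C1(Cc2ccccc2)CCN(c2cc(C(F)(F)F)ccc2CNC(=O)Nc2cccc3c2CC(O)CC3)CC1`: 10.1 nM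
- compound 3, `CN(C)C1(Cc2ccccc2)CCN(c2cc(C(F)(F)F)ccc2CNC(=O)Nc2ccc3c(c2)OCC3)CC1`: 31.3 nM

Among these three, compound 1 has the highest number, so it is the weakest of the set: the step of a 2.6-fold lower number from compound 1 to compound 3 (0.41 log units; beyond the scatter) and the step of an 8.0-fold lower number from compound 1 to compound 2 (0.90 log units; beyond the scatter) are both beyond the scatter. Each of those steps swaps the group on the amide-type nitrogen of the shared core for a two-ring group, and each time the number fell.

Compound 4, `CN(C)C1(Cc2ccccc2)CCN(c2cc(C(F)(F)F)ccc2CNC(=O)Nc2ccc3cnccc3c2)CC1`, makes a change of the same kind: isoquinolin-6-yl in place of 3-fluoro-4-(hydroxymethyl)phenyl on an amide-type nitrogen. Again a two-ring group replaces the single ring with its fluorine and hydroxymethyl. The measured steps bear on this only loosely, since the entering group here is aromatic in both rings and carries no hydroxyl, which neither compound 2 nor compound 3 shows. Still, both earlier swaps to two-ring groups lowered the number by a modest amount, so a modest fall is expected here too, with the step from compound 1 to compound 4 estimated as a 3.2-fold lower number from compound 1 to compound 4 (0.51 log units; beyond the scatter). Compound 4 is therefore expected to give about 25 nM in this assay, within a range of 8 nM to 80 nM.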

Compound 4, half-maximal effective concentration: 156 nM
The estimate for compound 4 lay 6.2-fold (0.80 log units) below the measured number; measured number outside the range, above it.
By their numbers in this assay, from the lowest: compound 2; then compound 3; then compounds 1 and 4 (each within the scatter of the next).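

Within the data shown here, with isoquinolin-6-yl on the amide-type nitrogen, a group of two rings brings no clear change from the single ring of compound 1 (a 1.9-fold higher number from compound 1 to compound 4 (0.28 log units; within the scatter)), so having two rings is not enough on its own at this position. Which two-ring group is used does matter, as shown by a modest step (a 5.0-fold higher number from compound 3 to compound 4 (0.70 log units; beyond the scatter)) and a large one (a 15-fold higher number from compound 2 to compound 4 (1.19 log units; beyond the scatter)), which separate groups that all have two rings. Nothing measured here explains these differences.

The compounds shown cannot tell whether the ring nitrogen of isoquinolin-6-yl matters, and naphthalen-2-yl, the same two rings of carbon only, would test that directly. As far as these compounds go, it also remains open whether a hydroxyl group on isoquinolin-6-yl would bring the number closer to that of compound 2.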